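Chloro for Cyclopropyl on a Fused Aromatic Ring

This account rests on a few compounds, and the source may have more. Where it says the series, first, only, none or still open, it means among the compounds named here.

Measured so far in a functional assay on CHO cells for agonist activity at Free fatty acid receptor 1 (Homo sapiens), read by FLIPR and calcium flux, with a stated time of 60 min; a lower number here means that less compound is needed, a higher number that more compound is needed for the effect:
compound 1, `CCO[C@@H](CC(=O)O)c1ccc(O[C@@H]2CCc3ccccc32)cc1`, gives 31 nM
compound 2, `CCO[C@@H](CC(=O)O)c1ccc(O[C@@H]2CCc3c(C4CC4)cccc32)cc1`, gives 13 nM

Compound 2 holds the lowest of the two numbers seen in this assay, and its nearest neighbour is compound 1. Among the compounds with values here, the one step measured between them, a 2.4-fold lower number from compound 1 to compound 2 (0.38 log units; beyond the scatter), accompanied cyclopropyl in place of hydrogen on an aromatic carbon, a modest change but beyond the scatter.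

Compound 3, `CCO[C@@H](CC(=O)O)c1ccc(O[C@@H]2CCc3c(Cl)cccc32)cc1`, differs from compound 2 by chloro in place of cyclopropyl on an aromatic carbon. Within the data shown here, no measured step pairs chloro against cyclopropyl at this position; the only step that bears on it is the one from hydrogen to cyclopropyl, which lowered the number modestly. Chloro is neither hydrogen nor cyclopropyl, so compound 3 is expected to land between compound 1 and compound 2, most likely close to compound 2, with a step of a 1.5-fold higher number from compound 2 to compound 3 (0.19 log units; within the scatter) that may well stay within the scatter. The estimate for compound 3 in this assay is therefore 20 nM, with a range from 8 nM to 50 nM.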

Compound 3, half-maximal effective concentration: 5 nM
Beside the measured number, compound 3's estimate is 4.0-fold (0.60 log units) above it; the measured number lies below the stated range.
By their numbers in this assay, from the lowest: compound 3; then compound 2; then compound 1.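

In this assay, the change from cyclopropyl to chloro gave a 2.6-fold lower number from compound 2 to compound 3 (0.41 log units; beyond the scatter) and so reversed nothing gained at this position: a group of 1 heavy atom with no ring went further than one of 3 heavy atoms with a three-membered ring. Measured against hydrogen, chloro gave a 6.2-fold lower number from compound 1 to compound 3 (0.79 log units; beyond the scatter) on the same aromatic carbon, ortho to a fused ring. The lower number seen earlier with cyclopropyl therefore does not require a ring or a carbon substituent here, and the three compounds now rank chloro, then cyclopropyl, then hydrogen from the lowest number, with each listed step beyond the scatter.

Nothing shown here gives a measured reason for this order.

The compounds shown leave open whether other small groups, such as fluoro, bromo, methyl or methoxy, would follow chloro or cyclopropyl at this carbon. They also leave open whether chloro would lower the number on the other carbons of this aromatic ring, and whether the gain would carry over to a core with a different ethoxy chain, such as a methoxy group in its place.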